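This account rests on a few compounds, and the source may have more. Where it says the series, first, only, none or still open, it means among the compounds named here.

Of the compounds shown here, three sharing one core have been measured in a functional assay on HeLa cells (Homo sapiens) for cytotoxicity, read by MTT assay, with a stated time of 72 h; on this read-out lower numbers stand for stronger inhibition and higher numbers for weaker inhibition. Compound 1, `[N-]=[N+]=NCc1nnc(-c2cc(S(N)(=O)=O)c(SCc3ccccc3)cc2Cl)o1`, gives 115000 nM. Compound 2, `CCOC(=O)c1cn(Cc2nnc(-c3cc(S(N)(=O)=O)c(SCc4ccccc4)cc3Cl)o2)nn1`, gives 122000 nM. Compound 3, `NS(=O)(=O)c1cc(-c2nnc(CNS(=O)(=O)c3ccc(Cl)cc3)o2)c(Cl)cc1SCc1ccccc1`, gives 24000 nM, and this is the lowest of the three numbers, so compound 3 stands as the most potent of the three on this read-out.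

Compound 4, `NS(=O)(=O)c1cc(-c2nnc(/C=C/c3cccc(Cl)c3)o2)c(Cl)cc1SCc1ccccc1`, differs from compound 3 in one place: 2-(3-chlorophenyl)ethenyl in place of (((4-chlorophenyl)sulfonyl)amino)methyl on an aromatic carbon.

Going by the values given here, no measured step replaces this kind of group, but two steps touch the same side of the core. The steps of a 4.8-fold lower number from compound 1 to compound 3 (0.68 log units; beyond the scatter) and a 5.1-fold lower number from compound 2 to compound 3 (0.71 log units; beyond the scatter) show that putting the ((4-chlorophenyl)sulfonyl)amino group in place of a smaller group lowers the number modestly. Compound 4 gives up that group while keeping an aromatic ring on that side, so the number is expected to lie between compound 3 and compounds 1 and 2, with the direction uncertain.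

The step of a 2.1-fold higher number from compound 3 to compound 4 (0.32 log units; beyond the scatter) is therefore expected to be a moderate rise. Compound 4 is estimated at 50000 nM, within a range from 15000 nM to 160000 nM.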

Compound 4, half-maximal inhibitory concentration: 16000 nM
Compound 4: the middle estimate sits 3.1-fold (0.49 log units) above what was measured, and the stated range covers the measured number.
By their numbers in this assay, from the lowest: compounds 4 and 3 (each within the scatter of the next); then compounds 1 and 2 (each within the scatter of the next).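

In this assay, the aromatic carbon of the five-membered ring tolerates a large change: 2-(3-chlorophenyl)ethenyl can stand in place of (((4-chlorophenyl)sulfonyl)amino)methyl with a 1.5-fold lower number from compound 3 to compound 4 (0.18 log units; within the scatter), so the two groups cannot be told apart on this read-out even though the entering group has no hydrogen-bond donors or acceptors and the leaving group has both. The new group also keeps the advantage over the two smaller-numbered comparisons seen earlier only for the sulfonyl compound, with a 7.6-fold lower number from compound 2 to compound 4 (0.88 log units; beyond the scatter) and a 7.2-fold lower number from compound 1 to compound 4 (0.86 log units; beyond the scatter), which shows that a sulfonyl group is not required for a number at this level among these four compounds. No measurement at hand explains why these groups behave alike.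

On these data alone, it remains open which part of 2-(3-chlorophenyl)ethenyl matters, the double bond or the chlorine, and a saturated ethyl link or an unsubstituted phenyl ring would separate the two. As far as these compounds go, how an amine or a carboxylic acid at this position would compare also stays unknown.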